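This account rests on a few compounds, and the source may have more. Where it says the series, first, only, none or still open, it means among the compounds named here.

Measured compounds:
- Compound 1 `N#CCCCn1c(Cn2c(=O)n(-c3ccc(C(=O)NC4CC4)cc3)c3ccncc32)cc2cc(Cl)ccc21`: in an ADME assay on HeLa cells (Homo sapiens) for cytotoxicity, read by ATP content, with a stated time of 3 days (a higher number here means that more compound is tolerated, a lower number that less compound is tolerated), compound 1 reaches > 50000 nM, a limit of the assay and not a number.
- Compound 2 `N#CCCCn1c(Cn2c(=O)n(-c3ccncc3F)c3ccncc32)cc2cc(Cl)ccc21`: in this assay compound 2 reaches > 50000 nM, likewise a limit.

Within the data shown here, compound 2 stands at the limit in this assay, as does the one other value shown (the limit of > 50000 nM in this assay, at which 2 of the 2 values shown sit). Among the measured compounds shown here, the single measured step, a step that the two limits leave unreadable from compound 1 to compound 2, runs between two limits and its size cannot be read. Compound 3 `N#CCCCn1c(Cn2c(=O)n(-c3ncccn3)c3ccncc32)cc2cc(Cl)ccc21` differs from compound 2 by pyrimidin-2-yl in place of 3-fluoropyridin-4-yl on an aromatic nitrogen. The one step shown bears on this exchange only in that both of its ends sit at the limit (the limit of > 50000 nM in this assay, at which 2 of the 2 values shown sit); no size can be drawn from it. In this assay the expectation is therefore no readable step, with compound 3 expected to sit at the limit as well. Compound 3 is estimated at 60000 nM, within 30000 nM to 150000 nM, which would be an expected step that the limit leaves unreadable from compound 2 to compound 3.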

Compound 3, half-maximal cytotoxic concentration: > 50000 nM
Compound 3 ended at the assay's limit; the forecaster's own chance of this, stated with the estimate: 85%; the middle value is on the limit's open side.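

No size can be read for the steps from compound 2 to compound 3 or from compound 1 to compound 3, each of which runs between two assay limits: the limit of > 50000 nM in this assay, at which 3 of the 3 values shown sit.

The compounds shown leave open whether pyrimidin-2-yl, 3-fluoropyridin-4-yl and 4-(cyclopropylcarbamoyl)phenyl differ at all in this assay.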